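Swapping 4-Bromophenyl for 3-Chlorophenyl at the Assay Limit

The compounds below may be only part of what the source reports. "The series", "measured", "known", "first", "only" and "open" are said of these compounds alone.

Compound 1 `COc1ccc(-c2nc3cccc(-c4cc(OC)c(OC)c(OC)c4)c3o2)cc1OC` and compound 2 `COc1cc(-c2cccc3nc(-c4ccc(Br)cc4)oc23)cc(OC)c1OC` share one core and differ in a single aromatic group. In a functional assay on NCI-H460 cells (Homo sapiens) for antiproliferative activity, read by MTT assay, with a stated time of 48 h (a lower number here means a stronger inhibitor, a higher number a weaker inhibitor), compound 1 gives > 25000 nM as a limit of the assay and not a number. Compound 2 gives > 25000 nM as well, again only a limit. The picture so far is the limit of > 25000 nM in this assay, at which 2 of the 2 values shown sit, and nothing more.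

Compound 3 `COc1cc(-c2cccc3nc(-c4cccc(Cl)c4)oc23)cc(OC)c1OC` keeps the core and carries 3-chlorophenyl in place of 4-bromophenyl on an aromatic carbon, next to the ring nitrogen and next to the ring oxygen (3-chlorophenyl in place of 4-bromophenyl on an aromatic carbon). Among the measured compounds shown here, the only measured step that bears on this is a step that the two limits leave unreadable from compound 1 to compound 2 and it hands on no size, so no step beyond the scatter can be foreseen in this assay in either direction. The estimated change is a number no higher from compound 2 to compound 3 (the limit leaves the size open) on this reasoning. Compound 3 is expected at 25000 nM (estimated range 10000 nM to 50000 nM) and may well again be reported only as a limit.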

Compound 3, half-maximal inhibitory concentration: > 25000 nM
Compound 3 was reported as a limit; the forecaster's own chance of this, stated with the estimate: 75%; the middle value sits exactly at the limit.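

In this assay compound 3 is reported only as a limit, just as compound 1 and compound 2 are, so no step among these three compounds can be read: the limit of > 25000 nM in this assay, at which 3 of the 3 values shown sit. The compounds shown leave open how strongly any of them acts and whether changing this aromatic group matters at all.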